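The compounds below may be only part of what the source reports. "The series", "measured", "known", "first", "only" and "open" are said of these compounds alone.

Of the compounds shown here, three built on the same core have been tested in an assay on Midbrain with Type-2 angiotensin II receptor (Rattus norvegicus) as the target; a higher number here means a weaker inhibitor, a lower number a stronger inhibitor. Compound 1 `CCc1nc2c(C)cc(C)nc2n1Cc1ccc(OC(C(=O)O)c2ccccc2)c(Cl)c1` gives 720 nM, the highest of the three numbers, so it is the weakest of the set on this readout. Compound 2 `CCc1cc(Cn2c(CC)nc3c(C)cc(C)nc32)ccc1OC(C(=O)O)c1ccccc1` gives 410 nM in this assay, and compound 3 `CCc1nc2c(C)cc(C)nc2n1Cc1ccc(OC(C(=O)O)c2ccccc2)c(C(=O)c2ccccc2)c1` gives 60 nM. Between the measured compounds, the step is a 1.8-fold lower number from compound 1 to compound 2 (0.24 log units; within the scatter); the step is a 12-fold lower number from compound 1 to compound 3 (1.08 log units; beyond the scatter); and the step is a 6.8-fold lower number from compound 2 to compound 3 (0.83 log units; beyond the scatter).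

Compound 4 `CCOc1cc(Cn2c(CC)nc3c(C)cc(C)nc32)ccc1OC(C(=O)O)c1ccccc1` differs from compound 1 at a single point: ethoxy in place of chloro on an aromatic carbon. Going by the values given here, of the measured steps, the one from compound 1 to compound 2 bears most on this change, as it too swaps chloro for a small group with no ring, and that step stayed within the scatter. Among the compounds with values here, the only step that left the scatter, from compound 1 to compound 3, brought in a group carrying a ring, which ethoxy does not. A step within the scatter, or at most a slightly lower number, is therefore expected for compound 4. The expected change is a 1.6-fold lower number from compound 1 to compound 4 (0.20 log units; within the scatter). Compound 4 is estimated at 450 nM in this assay, with a range from 200 nM to 1000 nM.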

Compound 4, half-maximal inhibitory concentration: 1200 nM
Compound 4: the middle estimate sits 2.7-fold (0.43 log units) below what was measured; the whole stated range lies below it.
By their numbers in this assay, from the lowest: compound 3; then compounds 2, 1 and 4 (each within the scatter of the next, the first and the last beyond it).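

Ethoxy in place of chloro, on an aromatic carbon ortho to a large group and meta to a large group, leaves the number in this assay within the scatter (a 1.7-fold higher number from compound 1 to compound 4 (0.22 log units; within the scatter)), so this larger group with one hydrogen-bond acceptor gives no clear change from chloro. The ethoxy and ethyl groups, both without a ring, can nevertheless be told apart at this position (a 2.9-fold higher number from compound 2 to compound 4 (0.47 log units; beyond the scatter)), so the absence of a ring does not by itself place two groups within the scatter of each other, even though compound 1 lies within the scatter of both compound 2 and compound 4. The gap to the benzoyl group is much wider (a 20-fold higher number from compound 3 to compound 4 (1.30 log units; beyond the scatter)), and compound 3, whose group alone carries a ring, now stands apart from all three ring-free compounds only in the sense that its steps to compounds 1 and 4 are large and its step to compound 2 is modest.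

The compounds shown leave open whether the low number of compound 3 goes with the ring, the carbonyl or the two together, which a phenyl group and an acetyl group at this position would help to separate. Nothing available here explains why these groups differ in this assay.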